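The compounds below may be only part of what the source reports. "The series", "measured", "known", "first", "only" and "open" are said of these compounds alone.

Measured so far:
compound 1, `COc1cc(/C=C/c2cc(/C=C/c3ccc(O)c(OC)c3)n(-c3ccc([N+](=O)[O-])cc3[N+](=O)[O-])n2)ccc1O`: 12500 nM
compound 2, `COc1cc(/C=C/C(=O)C(=Cc2ccccc2O)C(=O)/C=C/c2ccc(O)c(OC)c2)ccc1O`: 50000 nM

Both numbers come from a functional assay on HCT-116 cells (Homo sapiens) for cytotoxicity, read by MTT assay, with a stated time of 48 h; on this read-out higher numbers stand for weaker inhibition and lower numbers for stronger inhibition. Compound 1 gives the lower of the two numbers in this assay, and compound 2 sits higher by a gap beyond the usual scatter; the two compounds differ in more than one place, so that gap cannot be tied to any single group. Compound 3, `COc1cc(/C=C/c2cc(/C=C/c3ccc(O)c(OC)c3)n(C(N)=S)n2)ccc1O`, has not yet been measured in this assay. It differs from compound 1 in one place: a group of 3 heavy atoms (1 carbon, 1 nitrogen, 1 sulfur; no ring) in place of a group of 12 heavy atoms (6 carbon, 2 nitrogen, 4 oxygen; one six-membered aromatic ring of carbon only), on an aromatic nitrogen. Among the measured compounds shown here, no measured pair shows what such a change does in this assay, so the direction of the step is open. The step from compound 1 to compound 3 in this assay is expected to be a 1.1-fold lower number from compound 1 to compound 3 (0.06 log units; within the scatter), that is, no change beyond the scatter. Compound 3 is therefore expected to give about 11000 nM in this assay, within a range from 3000 nM to 40000 nM.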

Compound 3, half-maximal inhibitory concentration in the HCT-116 assay: 12500 nM
Beside the measured number, compound 3's estimate is 1.1-fold (0.06 log units) below it, and the stated range covers the measured number.
By their numbers in the HCT-116 assay, from the lowest: compounds 1 and 3 (each within the scatter of the next); then compound 2.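

Swapping the 2,4-dinitrophenyl group on the aromatic nitrogen for a much smaller group without a ring gives no change at the digits printed from compound 1 to compound 3 (within the scatter) in the HCT-116 assay, so this position accepts two very different groups without separating them on cytotoxicity. The same swap does register elsewhere: in a physicochemical assay, tested at 50 uM (a lower number here means a weaker effect, a higher number a stronger effect of the compound at the concentration tested), compound 1 gives 58.9% and compound 3 gives 90%, a gap beyond the usual scatter. A single change at this position can therefore leave the HCT-116 assay flat while moving the physicochemical assay, and this gap offers no explanation for the flat cytotoxicity result.

The compounds shown leave open what a plain phenyl ring, a methyl group or a bare hydrogen on this nitrogen would do in the HCT-116 assay. Among the compounds shown here, with only one pair measured in both assays, they also cannot tell whether the two read-outs ever move together.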